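Replacing fluoro with 4-methylpiperazin-1-yl on compound 1

This account rests on a few compounds, and the source may have more. Where it says the series, first, only, none or still open, it means among the compounds named here.

In an ADME assay on MCF7-DOX cells (Homo sapiens) for cytotoxicity, read by MTT assay, with a stated time of 48 h (on this read-out higher numbers stand for weaker inhibition and lower numbers for stronger inhibition), compound 1 (`COc1cc(OC)c(C(=O)/C=C/c2cccc(F)c2)c(O)c1CC=C(C)C`) gives 45400 nM and shows no clear separation from the other measured compounds. Compound 2 (`COc1cc(OC)c(C(=O)/C=C/c2ccc(C(F)(F)F)cc2)c(O)c1CC=C(C)C`) gives 73700 nM and compound 3 (`COc1cc(OC)c(C(=O)/C=C/c2ccc(OC)c(OC)c2OC)c(O)c1CC=C(C)C`) gives 62700 nM on the same read-out, so all three numbers sit close together.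

Compound 4 (`COc1cc(OC)c(C(=O)/C=C/c2cccc(N3CCN(C)CC3)c2)c(O)c1CC=C(C)C`) has 4-methylpiperazin-1-yl in place of fluoro on an aromatic carbon, meta to a large group. The counted change is 4-methylpiperazin-1-yl in place of fluoro on an aromatic carbon and it is much larger than a swap of small substituents.

For the measured compounds named here, the only measured single-place step is a 1.6-fold higher number from compound 1 to compound 2 (0.21 log units; within the scatter) and it stays within the scatter. It exchanges 3-fluorophenyl for 4-(trifluoromethyl)phenyl, so it bears only loosely on the new group. Going by the values given here, no measured compound carries a non-aromatic ring at this place, which leaves the direction open.

Among the compounds with values here, with that step as the sole guide, no change beyond the scatter is expected in this assay for this swap. The expected step is a 1.1-fold lower number from compound 1 to compound 4 (0.05 log units; within the scatter) on this evidence. Within the data shown here, the range is kept wide, as the entering group has no measured precedent. For compound 4 the estimated value is 40000 nM with an expected range from 14000 nM to 90000 nM in this series.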

Compound 4, half-maximal inhibitory concentration: > 100000 nM
Compound 4: a limit, no number (the forecaster's own chance of this, stated with the estimate: 10%); at least 2.5-fold (0.39 log units) between middle value and limit.
By their numbers in this assay, from the lowest: compounds 1, 3 and 2 (each within the scatter of the next). At a limit, above all of these: compound 4.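

For the compounds shown here, putting 4-methylpiperazin-1-yl in place of fluoro on this aromatic carbon gives an at least 2.2-fold higher number from compound 1 to compound 4 (0.34 log units; beyond the scatter) in this assay, the only step so far that lies beyond the scatter. Compounds 1, 3 and 2 each sit within the scatter of the next, so they gave no sign that the read-out could move at all, whereas this change shows that the position does not accept every group without a shift towards weaker inhibition. The reading of compound 4 is a limit of the assay and not a number, so the step gives only a lower bound on the change: the limit of > 100000 nM in this assay, at which 1 of the 4 values shown sits.

On these data alone, how far compound 4 lies past that limit cannot be read, and the size of the change at this position stays unknown. The compounds shown also include no morpholine, piperidine or dimethylamino group on this aromatic carbon, so the ring, the second nitrogen and the methyl on nitrogen cannot be told apart as the part of the entering group that goes with the step.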